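The source may report more compounds than this note shows. Statements on the series, on what has been measured and on what is new or still open speak of the compounds shown alone.

Compound 1 `Cc1cc(N2CCCCC2)c(S(C)(=O)=O)cc1C(=O)N=C(N)N`: 21 nM
Compound 2 `CCc1cc(N2CCCCC2)c(S(C)(=O)=O)cc1C(=O)N=C(N)N`: 25 nM
Compound 3 `CCc1cc(-n2ccc(=O)cc2)c(S(C)(=O)=O)cc1C(=O)N=C(N)N`: 930 nM

These three compounds were tested in a functional assay for inhibition of sodium/hydrogen exchanger (Oryctolagus cuniculus); on this read-out lower numbers stand for stronger inhibition and higher numbers for weaker inhibition. Compound 1 and compound 2 share a core and differ in one place only: hydrogen in place of methyl on a saturated chain carbon bound to an aromatic carbon. This change gave a 1.2-fold lower number from compound 2 to compound 1 (0.08 log units; within the scatter), so the two numbers cannot be told apart. Compound 2 and compound 3 differ in their cores at a single position: a group of 7 heavy atoms (5 carbon, 1 nitrogen, 1 oxygen; one six-membered aromatic ring with 1 hetero atom) in place of a group of 6 heavy atoms (5 carbon, 1 nitrogen; one six-membered non-aromatic ring with 1 hetero atom), on an aromatic carbon. This change gave a 37-fold higher number from compound 2 to compound 3 (1.57 log units; beyond the scatter), and compound 3 therefore stands highest of the three, beyond the scatter from both of the others.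

Compound 4 `Cc1cc(-n2ccc(=O)cc2)c(S(C)(=O)=O)cc1C(=O)N=C(N)N` has not yet been measured. It differs from compound 3 by hydrogen in place of methyl on a saturated chain carbon bound to an aromatic carbon. For the measured compounds named here, this is the same change, at the same place, as the one that turned compound 2 into compound 1. For compound 4 the expected step is a 1.2-fold lower number from compound 3 to compound 4 (0.07 log units; within the scatter), because the same change elsewhere gave a 1.2-fold lower number from compound 2 to compound 1 (0.08 log units; within the scatter). Compound 4 is therefore expected to give about 800 nM. The range expected for compound 4 runs from 350 nM to 1900 nM. This rests on a single measured pairing, so the expectation carries the usual uncertainty of such a comparison, and the measured number will show how far it holds.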

Compound 4, half-maximal inhibitory concentration: 75 nM
The estimate for compound 4 lay 11-fold (1.03 log units) above the measured number, outside the stated range (below it).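

A common working assumption is that a small change has about the same effect wherever it is made, but that does not hold here. Going from ethyl to methyl gave a 12-fold lower number from compound 3 to compound 4 (1.09 log units; beyond the scatter) in this assay, so the size of this step did not carry over from one core to the other: the same change on two cores in this assay, a 1.2-fold lower number (0.08 log units; within the scatter) from compound 2 to compound 1 and a 12-fold lower number (1.09 log units; beyond the scatter) from compound 3 to compound 4, 10-fold (1.02 log units) apart, beyond the scatter of two such steps

Seen from the other direction, exchanging the six-membered non-aromatic ring for the six-membered aromatic ring gave a 3.6-fold higher number from compound 1 to compound 4 (0.55 log units; beyond the scatter), so the effect of the ring exchange also depends on whether the chain is ethyl or methyl: the same change on two cores in this assay, a 37-fold higher number (1.57 log units; beyond the scatter) from compound 2 to compound 3 and a 3.6-fold higher number (0.55 log units; beyond the scatter) from compound 1 to compound 4, 10-fold (1.02 log units) apart, beyond the scatter of two such steps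

The two changes therefore cannot simply be added together in this series, but these four compounds do not show why the cores respond differently, nor whether other changes would behave in the same way.

The compounds shown leave open how a longer chain such as propyl, in place of ethyl or methyl, would behave on each core. They also leave open whether a dimethylamino group, in place of either ring, would follow the core of compound 1 or the core of compound 4 when ethyl changes to methyl.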